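The source may report more compounds than this note shows. Statements on the series, on what has been measured and on what is new or still open speak of the compounds shown alone.

Compound 2 `O=C(NCc1ccc(CNS(=O)(=O)c2ccccc2Cl)cc1)c1ccc(CNc2ncccn2)cc1` stands in an assay on MDA-MB-231 cells for binding affinity to C-X-C chemokine receptor type 4 (Homo sapiens), read by microscopy, with stated times of 10 min and 30 min (on this read-out higher numbers stand for an effect only at larger amounts of compound and lower numbers for an effect already at smaller amounts), at 1000 nM. Going by the values given here, compound 1 `O=C(NCc1ccc(CNS(=O)(=O)c2ccc([N+](=O)[O-])cc2)cc1)c1ccc(CNc2ncccn2)cc1` in this assay gives 1000 nM, and the step of no change at the digits printed from compound 1 to compound 2 (within the scatter) is the only measured change at the group on the sulfonyl sulfur. Compound 3 `O=C(NCc1ccc(CNS(=O)(=O)c2ccc3c(c2)CCO3)cc1)c1ccc(CNc2ncccn2)cc1` differs from compound 2 at that same position: a group of 9 heavy atoms (8 carbon, 1 oxygen; one five-membered non-aromatic ring with 1 hetero atom, one six-membered aromatic ring of carbon only) in place of a group of 7 heavy atoms (6 carbon, 1 chlorine; one six-membered aromatic ring of carbon only), on a sulfonyl sulfur. Among the compounds with values here, the one step that bears on this change showed nothing beyond the scatter between compound 1 and compound 2, so no shift beyond the scatter is expected here either. Compound 3 is estimated at 1000 nM, range 400 nM to 2500 nM. The expected step is no change at the digits printed from compound 2 to compound 3 (within the scatter).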

Compound 3, effective concentration (reported as EC, without a stated level of effect): 1000 nM
Compound 3: middle estimate and measured number agree at the digits printed; the range from low to high includes it.
By their numbers in this assay, from the lowest: compounds 1, 2 and 3 (each within the scatter of the next).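

On a sulfonyl sulfur, a five-membered non-aromatic ring with 1 hetero atom and a hydrogen-bond acceptor enter in this assay with no change at the digits printed from compound 2 to compound 3 (within the scatter). Measured against the 4-nitrophenyl group, the same change gives no change at the digits printed from compound 1 to compound 3 (within the scatter). No measured evidence accounts for this result. Still open, on these data alone, is whether a longer alkyl chain in place of the aromatic ring, or a group carrying an amine or a carboxylic acid, on the sulfonyl sulfur would move the value beyond the scatter.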